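A few compounds are considered here, and "the series" means these few. Any claim that something is new, unique, unknown or untested is made for them only; others in the source may bear on it.

In a functional assay on JAR cells (Homo sapiens) for inhibition (on this read-out lower numbers stand for stronger inhibition and higher numbers for weaker inhibition), compound 1 (`CCOC(=O)C1=C(Nc2ccccc2)S/C(=C\C2CCCCC2)C1=O`) gives 3700 nM, while compound 2 (`CCOC(=O)C1=C(Nc2ccccc2)S/C(=C\c2cc3ncccc3[nH]2)C1=O`) gives 9600 nM, the higher of the two numbers. Compound 3 (`CCOC(=O)C1=C(Nc2ccccc2)S/C(=C\c2ccc(F)c(C#N)c2)C1=O`) keeps the shared core but carries 3-cyano-4-fluorophenyl at the same place: a group of 9 heavy atoms (7 carbon, 1 nitrogen, 1 fluorine; one six-membered aromatic ring of carbon only) in place of a group of 9 heavy atoms (7 carbon, 2 nitrogen; one five-membered aromatic ring with 1 hetero atom, one six-membered aromatic ring with 1 hetero atom), on a double-bonded chain carbon bound to a double-bonded ring carbon. Among the measured compounds shown here, the only measured step at this place is a 2.6-fold higher number from compound 1 to compound 2 (0.41 log units; beyond the scatter), a modest one, so a change of similar modest size is expected, more likely towards a lower number than that of compound 2, which gives 9600 nM. The expected step is a 1.9-fold lower number from compound 2 to compound 3 (0.28 log units; within the scatter). For compound 3 the estimated value is 5000 nM, with an expected range of 1500 nM to 15000 nM.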

Compound 3, half-maximal inhibitory concentration: 1500 nM
The estimate for compound 3 lay 3.3-fold (0.52 log units) above the measured number; the measured number falls inside the stated range.
By their numbers in this assay, from the lowest: compound 3; then compound 1; then compound 2.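

In this assay, the group at this place can push the number down as well as up: 3-cyano-4-fluorophenyl replacing the two-ring group gives a 6.4-fold lower number from compound 2 to compound 3 (0.81 log units; beyond the scatter), and replacing cyclohexyl it gives a 2.5-fold lower number from compound 1 to compound 3 (0.39 log units; beyond the scatter). Compound 2 and compound 3 both carry aromatic rings yet fall on opposite sides of compound 1, so having an aromatic ring here does not by itself set the number. Nothing available explains this difference. The compounds shown do not separate the contribution of the nitrile from that of the fluorine, and they leave open how a plain phenyl or a ring bearing a carboxylic acid would compare.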